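A few compounds are considered here, and "the series" means these few. Any claim that something is new, unique, unknown or untested is made for them only; others in the source may bear on it.

Compound 1, `CCn1cc(-c2nc3ccccc3[nH]2)c(=O)c2cc(F)c(N3CCNCC3)cc21`, in a functional assay on HeLa cells (Homo sapiens) for cytotoxicity, read by sulforhodamine B assay, with a stated time of 48 h (on this read-out lower numbers stand for stronger inhibition and higher numbers for weaker inhibition), gives > 10000 nM, which is a limit of the assay rather than a number.
Compound 2, `CCn1cc(-c2nc3ccc([N+](=O)[O-])cc3o2)c(=O)c2cc(F)c(N3CCNC(C)C3)c(F)c21`, gives 2400 nM in this assay.
Compound 3, `CCn1cc(-c2nc3ccc([N+](=O)[O-])cc3s2)c(=O)c2cc(F)c(N3CCNC(C)C3)c(F)c21`, gives 9900 nM in this assay.

Among the three values shown, compound 1 is the one that returned no number at all: its result is a limit, as the limit of > 10000 nM in this assay, at which 1 of the 3 values shown sits, records, and so it stands at the weak end of what the assay reports, with no figure of its own to compare. Compound 2 and compound 3 give numbers, and what separates those two is not the subject here.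

Compound 4, `CCn1cc(-c2nc3ccc(N)cc3[nH]2)c(=O)c2cc(F)c(N3CCNCC3)cc21`, differs from compound 1 in one place: amino in place of hydrogen on an aromatic carbon. The rest of the shared core, with its ethyl group, its fluorine and its piperazine, is kept as it stands in compound 1. Among the compounds with values here, no measured pair in this set shows the effect of that change, so the step from compound 1 to compound 4 in this assay is expected to be small, with no clear direction, and most likely within the scatter: the estimate is a number no higher from compound 1 to compound 4 (the limit leaves the size open). Compound 4 is therefore expected to give about 10000 nM in this assay, within a range from 3000 nM to 30000 nM, and there is a good chance that the assay again reports only a limit.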

Compound 4, half-maximal inhibitory concentration: > 10000 nM
Compound 4: only a limit was reported (the forecaster's own chance of this, stated with the estimate: 60%); the middle value sits exactly at the limit.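

Compound 4, like compound 1, returns only a limit in this assay, not a number: the limit of > 10000 nM in this assay, at which 2 of the 4 values shown sit. Within the data shown here, no step from compound 1 to compound 4 can be read from these two limits. The compounds shown leave open whether amino in place of hydrogen on an aromatic carbon shifts the value at all, and in which direction.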